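Cycloheptyl Replaces the Aryl Amide: Cytotoxicity Expectation

The source may hold more compounds than are shown below. What is called first, only, known or untested is meant among the compounds shown, and "the series" means these compounds.

Compound 1 `Cc1nc(C(NC(=O)C(=O)Nc2ccc(F)c(Cl)c2)C2CCCCN2)sc1CO`: > 77800 nM
Compound 2 `Cc1nc(C(NC(=O)C(=O)Nc2ccc(F)cc2F)C2CCCCN2)sc1CCO`: > 105000 nM
Compound 3 `Cc1nc(C(NC(=O)C(=O)Nc2ccc(F)c(Cl)c2)C2CCCCN2)sc1CCO`: 94700 nM

In an ADME assay on MT2 cells (Homo sapiens) for cytotoxicity, read by XTT assay, with a stated time of 4 days (a lower number here means that less compound is tolerated, a higher number that more compound is tolerated), compound 1 gives > 77800 nM, a limit of the assay rather than a number. Compound 2 likewise gives only a limit, > 105000 nM. Compound 3 alone gives a number, 94700 nM. Compound 1 therefore stands at a limit, shown as the limit of > 77800 nM in this assay, at which 1 of the 3 values shown sits, and the step that the limit leaves unreadable from compound 1 to compound 3 cannot be sized. The other measured step, an at least 1.1-fold lower number from compound 2 to compound 3 (0.04 log units; that floor lies within the scatter), concerns the aryl group on the same amide-type nitrogen and stays within the scatter.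

Compound 4 `Cc1nc(C(NC(=O)C(=O)NC2CCCCCC2)C2CCCCN2)sc1CO` differs from compound 1 by cycloheptyl in place of 3-chloro-4-fluorophenyl on an amide-type nitrogen. Going by the values given here, no measured step exchanges the aryl group for a saturated ring, so the only guidance is the small aryl-to-aryl step from compound 2 to compound 3 and the fact that all three compounds sit at or near the limits. In this assay no step beyond the scatter is expected. Compound 4 is expected near 85000 nM, with a range from 35000 nM to 160000 nM. The expected step is a step that the limit leaves unreadable from compound 1 to compound 4.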

Compound 4, half-maximal cytotoxic concentration: > 90000 nM
Compound 4: only a limit was reported (the forecaster's own chance of this, stated with the estimate: 60%); middle value at least 1.0-fold (0.02 log units) from the limit.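

Compound 1 and compound 4 both stand at limits in this assay rather than at numbers, so the step between them cannot be read. The compounds shown leave open whether cycloheptyl in place of 3-chloro-4-fluorophenyl on an amide-type nitrogen changes the concentration tolerated at all.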